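The source may hold more compounds than are shown below. What is called first, only, known or untested is meant among the compounds shown, and "the series" means these compounds.

Of the compounds shown here, three share one core and have been tested in an ADME assay on HepG2 2.2.15 cells (Homo sapiens) for cytotoxicity; a lower number here means that less compound is tolerated, a higher number that more compound is tolerated. Compound 1 `COCCc1ccc(OC(c2ccc(Cl)cc2)c2cnc(NC(=O)OC(C)(C)C)s2)cc1` carries a 4-(2-methoxyethyl)phenyl group on an oxygen on a saturated carbon. In this assay compound 1 gives > 50000 nM, which is a limit of the assay and not a number. Compound 2 `Cc1cc(Br)cc(OC(c2ccc(Cl)cc2)c2cnc(NC(=O)OC(C)(C)C)s2)c1` carries 3-bromo-5-methylphenyl in place of that group. In this assay compound 2 gives > 50000 nM, again a limit rather than a number. The step that the two limits leave unreadable from compound 1 to compound 2 therefore cannot be read in size. Compound 3 `CCN(CC)C(=O)Nc1ncc(C(Oc2ccc3cc(Br)ccc3c2)c2ccc(Cl)cc2)s1` carries a diethylcarbamoyl on a nitrogen on an aromatic ring. In this assay compound 3 is recorded as "not toxic" (no number reported), a word without a number. Of the three compounds, two sit at the same point, as the limit of > 50000 nM in this assay, at which 2 of the 3 values shown sit, shows, and compound 3 stands beside them without a number of its own.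

Compound 4 `O=S(=O)(Nc1ncc(C(Oc2ccc3cc(Br)ccc3c2)c2ccc(Cl)cc2)s1)c1ccccc1` has not yet been measured. It differs from compound 3 in one place: phenylsulfonyl in place of diethylcarbamoyl on a nitrogen on an aromatic ring. No measured step touches this change, and the one step that exists is unreadable, so no size or direction can be drawn from it; the data offer only that none of the three compounds has shown a readable toxicity. Compound 4 is therefore expected to give 60000 nM in this assay, within a range from 20000 nM to 150000 nM, with a limit rather than a number the likeliest outcome.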

Compound 4, half-maximal cytotoxic concentration: > 50000 nM
Compound 4 ended at the assay's limit (the forecaster's own chance of this, stated with the estimate: 75%); the middle value is on the limit's open side.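

In this assay compound 4 gives > 50000 nM, which is a limit of the assay and not a number. Within the data shown here, compound 3 is recorded only as "not toxic" (no number reported), so no step to compound 4 can be read. The compounds shown leave open at what concentration any of them would become toxic to these cells, and whether phenylsulfonyl in place of diethylcarbamoyl changes that concentration.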